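Benzyl substituent change in a two-compound antagonist series

This account rests on a few compounds, and the source may have more. Where it says the series, first, only, none or still open, it means among the compounds named here.

Measured so far:
- Compound 1 `COc1ccc(Cc2nnc(CN(c3cccc(C(F)(F)F)c3C)S(=O)(=O)c3ccc(C)cc3)o2)cc1`: 398 nM in a functional assay on CHO cells for antagonist activity at prostaglandin E2 receptor EP1 subtype (Homo sapiens), read by FLIPR and calcium flux; on this read-out lower numbers stand for stronger inhibition and higher numbers for weaker inhibition
- Compound 2 `Cc1ccc(S(=O)(=O)N(Cc2nnc(Cc3ccc(N(C)C)cc3)o2)c2cccc(Cl)c2C)cc1`: 20 nM in this assay

For the measured compounds named here, compound 2 gives the lower of the two numbers; compound 1 sits at a higher value, a gap beyond the usual scatter, but the two differ in more than one place, so no single step is resolved.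

Compound 3 `Cc1ccc(S(=O)(=O)N(Cc2nnc(Cc3ccccc3Cl)o2)c2cccc(Cl)c2C)cc1` carries 2-chlorophenyl in place of 4-(dimethylamino)phenyl on a saturated chain carbon bound to an aromatic carbon relative to compound 2. Going by the values given here, with no measured pair isolating this change, the expected step of a 3.0-fold higher number from compound 2 to compound 3 (0.48 log units; beyond the scatter) is a modest weakening, possibly within scatter. For compound 3 a value of 60 nM is estimated, within 15 nM to 250 nM.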

Compound 3, inhibition constant: 398 nM
Compound 3: middle estimate off by 6.6-fold (0.82 log units), on the low side; measured number outside the range, above it.
By their numbers in this assay, from the lowest: compound 2; then compounds 1 and 3 (each within the scatter of the next).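

On a saturated chain carbon bound to an aromatic carbon, 2-chlorophenyl in place of 4-(dimethylamino)phenyl gives a 20-fold higher number from compound 2 to compound 3 (1.30 log units; beyond the scatter) in this assay. For the compounds shown here, this is the first single-place change resolved, and it shows that the read-out is sensitive to the aryl group at this place. No available evidence bears on what lies behind the step.

As far as these compounds go, whether the step follows from losing the dimethylamino group or from gaining the chlorine remains open. An unsubstituted phenyl at this place would separate the two.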